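The compounds below may be only part of what the source reports. "The series", "measured", "known", "first", "only" and "open" are said of these compounds alone.

Compound 2 `COc1cc(C=C2C(=O)N(c3ccc(Cl)cc3)N(c3ccc(Cl)cc3)C2=O)ccc1O` carries a 4-hydroxy-3-methoxyphenyl group on a double-bonded chain carbon bound to a double-bonded ring carbon. In a functional assay on MCF7 cells (Homo sapiens) for cytotoxicity, read by MTT assay, with a stated time of 72 h (a higher number here means a weaker inhibitor, a lower number a stronger inhibitor), compound 2 gives 22800 nM. Of the two numbers available this is the higher one. Its nearest neighbour is compound 3 `O=C1C(=Cc2ccco2)C(=O)N(c2ccc(Cl)cc2)N1c1ccc(Cl)cc1`, which gives 20300 nM in this assay, the gap being a 1.1-fold lower number from compound 2 to compound 3 (0.05 log units; within the scatter). Compound 1 `CN(C)c1ccc(C=C2C(=O)N(c3ccc(Cl)cc3)N(c3ccc(Cl)cc3)C2=O)cc1` gives only a limit in this assay, > 128000 nM, as noted by the limit of > 128000 nM in this assay, at which 1 of the 3 values shown sits. From that limit the measured steps are an at least 5.6-fold lower number from compound 1 to compound 2 (0.74 log units; beyond the scatter) and an at least 6.3-fold lower number from compound 1 to compound 3 (0.79 log units; beyond the scatter), both beyond the scatter, so the group on that chain carbon can move the number by at least a modest amount.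

Compound 4 `O=C1C(=C/C=C/c2ccccc2)C(=O)N(c2ccc(Cl)cc2)N1c1ccc(Cl)cc1` is the next member. The change from compound 2 is 2-phenylethenyl in place of 4-hydroxy-3-methoxyphenyl on a double-bonded chain carbon bound to a double-bonded ring carbon. Among the compounds with values here, no measured step exchanges an aryl group for a 2-phenylethenyl group, so none bears directly on it. The two steps from compound 1 show only that a 4-(dimethylamino)phenyl group does worse than either alternative, while compound 2 and compound 3 sit together. The step to compound 4 is therefore expected to be small, a 1.5-fold lower number from compound 2 to compound 4 (0.18 log units; within the scatter). Compound 4 is estimated at 15000 nM, with a range from 5000 nM to 50000 nM.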

Compound 4, half-maximal inhibitory concentration: 9400 nM
Beside the measured number, compound 4's estimate is 1.6-fold (0.20 log units) above it; the measured number falls inside the stated range.
By their numbers in this assay, from the lowest: compound 4; then compounds 3 and 2 (each within the scatter of the next). At a limit, above all of these: compound 1.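

In this assay, the position on a double-bonded chain carbon bound to a double-bonded ring carbon now separates the measured groups, which the earlier furan-2-yl and 4-hydroxy-3-methoxyphenyl pair could not do: the change to 2-phenylethenyl gives a 2.4-fold lower number from compound 2 to compound 4 (0.38 log units; beyond the scatter) and a 2.2-fold lower number from compound 3 to compound 4 (0.33 log units; beyond the scatter). Within the data shown here, the entering group has no hydrogen-bond donors or acceptors and one double bond outside aromatic rings, and it is the first group at this place to stand clear of both others, though only by a modest step. Against 4-(dimethylamino)phenyl the same change gives an at least 13-fold lower number from compound 1 to compound 4 (1.13 log units; beyond the scatter), and that step rests on a limit for compound 1: the limit of > 128000 nM in this assay, at which 1 of the 4 values shown sits.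

The compounds shown leave open whether the step belongs to the double bond of the chain or to the loss of the hydroxyl and methoxy groups, a question that a plain phenyl group at this place would separate. They also leave open whether a longer chain with a further double bond, or a 2-phenylethenyl group carrying a hydroxyl or an amine on its ring, would keep, extend or lose the step.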